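This account rests on a few compounds, and the source may have more. Where it says the series, first, only, none or still open, it means among the compounds named here.

The series shares one core, shown in compound 1 as `CC1=C(C(=O)OC(C)(C)C)C(c2ccoc2)NC(=O)N1` and in compound 2 as `CC1=C(C(=O)SC(C)C)C(c2ccoc2)NC(=O)N1`. In an assay on membranes from HeLa cells for displacement of a labelled ligand from adenosine receptor A3 (Homo sapiens), read by scintillation counting, with a stated time of 180 min, tested at 1 uM (a higher number here means more inhibition at the concentration tested (going by the name of the read-out), a lower number less inhibition), compound 1 gives 2%, and in the same assay compound 2 gives 3%. For the measured compounds named here, the one step between them, a number 1 percentage points higher from compound 1 to compound 2 (within the scatter), exchanges the group on the carbonyl carbon and leaves the read-out within the scatter, so compound 2 stands together with compound 1 at the low end of this assay, with neither number separable from the other.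

Compound 3, `CC1=C(C(=O)OC2CCCCC2)C(c2ccoc2)NC(=O)N1`, is not yet measured. Its difference from compound 2 is cyclohexyloxy in place of isopropylsulfanyl on a carbonyl carbon. Going by the values given here, the only measured step that bears on this change is a number 1 percentage points higher from compound 1 to compound 2 (within the scatter), since it also varies the group on that carbonyl carbon, and it was within the scatter. Compound 3 is therefore expected to show no change beyond the scatter in this assay, an expected step of no change at the digits printed from compound 2 to compound 3 (within the scatter). The estimate for compound 3 is 3%, in a range from -5% to 13%.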

Compound 3, a percentage reported as inhibition, at one concentration (the size of the read-out at that concentration, not a potency): 1%
For compound 3 the middle estimate is 2 percentage points above the measured one; the range from low to high includes it.
By their numbers in this assay, from the lowest: compounds 3, 1 and 2 (each within the scatter of the next).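

In this assay, the step to a larger group with one six-membered non-aromatic ring of carbon only, on a carbonyl carbon whose other neighbours are a double-bonded ring carbon, reads as a number 2 percentage points lower from compound 2 to compound 3 (within the scatter), so this change separates nothing, just as the earlier exchange at this place did not. The second comparison keeps the oxygen and alters only what sits on it, with cyclohexyl in place of tert-butyl, and it reads as a number 1 percentage points lower from compound 1 to compound 3 (within the scatter), which shows that a ring of carbon and a branched group on that oxygen also cannot be told apart in this read-out. Nothing measured here offers an explanation for why these numbers stay together.

Going by these compounds, whether an amine or a benzyloxy group on the same carbonyl carbon would lift the read-out away from this low level remains open, as does the effect of changes elsewhere on the shared core. With all three compounds at the low end at a single tested concentration, the data give no order among these groups and say nothing about potency.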